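The source may report more compounds than this note shows. Statements on the series, on what has been measured and on what is new or still open speak of the compounds shown alone.

Compound 1 `COc1cccc(CC2CCCCN2C(=O)n2ncc(C(O)(c3ccc(F)cc3)c3ccc(F)cc3)n2)c1`: 158 nM
Compound 2 `O=C(N1CCCCC1Cc1ccccc1)n1ncc(C(O)(c2ccccn2)c2ccccn2)n1`: 3160 nM
Compound 3 `O=C(N1CCCCC1COc1ccccc1)n1ncc(C(O)(c2ccccc2)c2ccccc2)n1`: 158 nM

In an assay on isolated protein for inhibition of Monoacylglycerol lipase ABHD6 (Homo sapiens), read by fluorescence (a lower number here means a stronger inhibitor, a higher number a weaker inhibitor), compound 1 gives 158 nM, level with compound 3 at the digits shown; together they carry the lowest numbers of the three. Compound 2 stands furthest away, with a higher number that lies well beyond the scatter. The piece follows the step from compound 1 to compound 4 `O=C(N1CCCCC1COc1ccccc1)n1ncc(C(O)(c2ccc(F)cc2)c2ccc(F)cc2)n1`, which is not yet measured in this assay. The change is phenoxy in place of 3-methoxyphenyl on a saturated chain carbon bound to a saturated ring carbon. Among the compounds with values here, no step between measured compounds isolates this change, so the expectation rests on compound 1 and on compound 3, whose values in this assay sit level. Compound 4 is therefore expected near both, with a step of a 1.2-fold lower number from compound 1 to compound 4 (0.08 log units; within the scatter) that stays within the scatter. The estimate for compound 4 is 130 nM, with a range from 40 nM to 400 nM.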

Compound 4, half-maximal inhibitory concentration: 200 nM
Beside the measured number, compound 4's estimate is 1.5-fold (0.19 log units) below it; low and high end bracket the measured number.
By their numbers in this assay, from the lowest: compounds 1, 3 and 4 (each within the scatter of the next); then compound 2.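

In this assay, putting phenoxy in place of 3-methoxyphenyl on a saturated chain carbon bound to a saturated ring carbon gives a 1.3-fold higher number from compound 1 to compound 4 (0.10 log units; within the scatter). Within the data shown here, this is the first direct reading of this change, and it shows that, with the rest of compound 1 kept, 3-methoxybenzyl and phenoxymethyl are interchangeable at this position in this assay. Nothing measured here explains this result. On these data alone, whether the same holds for other groups at this position, such as an amine, a carboxylic acid or a longer chain, remains open.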